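Dropping an Acetoxy Group from a Brominated Furanone

The source may report more compounds than this note shows. Statements on the series, on what has been measured and on what is new or still open speak of the compounds shown alone.

Three compounds from this study carry brominated carbon chains built on a small lactone or ketone core, and they were examined in a functional assay on BCA1 cells (Homo sapiens) for cytotoxicity; on this read-out lower numbers stand for an effect already at smaller amounts and higher numbers for an effect only at larger amounts of compound. Compound 1, with the structure `CCC[C@@H](OC(C)=O)C1=C(Br)/C(=C/Br)OC1=O`, has no result to show: in this assay compound 1 is recorded as "not determined" (no result reported). Compound 3, with the structure `CCCCC1=C(Br)C(OC)(C(Br)Br)OC1=O`, is in the same position, and in this assay compound 3 stands at "not determined" (no result reported). Only compound 2, with the structure `CCCCCCC(=O)C(Br)=C(Br)Br`, brings a reading, and that reading is a limit of the assay rather than a number: in this assay compound 2 gives > 20 ug/mL. Among the three values, therefore, one sits at the limit of > 20 ug/mL in this assay, at which 1 of the 3 values shown sits, and the other two are blank, so compound 1 has no place on any scale yet.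

Compound 4, with the structure `CCCCC1=C(Br)/C(=C/Br)OC1=O`, differs from compound 1 in a single spot: hydrogen in place of acetoxy on a saturated chain carbon bound to a double-bonded ring carbon and a saturated chain carbon. Among the measured compounds shown here, no measured pair differs in just this way, so no step can be drawn from the existing results. With nothing to anchor the change, no shift beyond the usual scatter is expected in this assay from removing the acetoxy group. Compound 4 is therefore estimated to give about 15 ug/mL in this assay, within a range from 4 ug/mL to 40 ug/mL.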

Compound 4, concentration for half-maximal effect: 9.8 ug/mL
Beside the measured number, compound 4's estimate is 1.5-fold (0.18 log units) above it; measured number inside the range.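

No step can be read from compound 1 to compound 4: in this assay compound 4 gives 9.8 ug/mL, while compound 1 has no number. Compound 2 offers only a limit: the limit of > 20 ug/mL in this assay, at which 1 of the 4 values shown sits.

The compounds shown leave open whether hydrogen in place of acetoxy shifts the reading in this assay at all.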